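Swapping the ether side chain on a nitro-bearing aryl sulfonamide

The compounds below may be only part of what the source reports. "The series", "measured", "known", "first", "only" and "open" are said of these compounds alone.

Three compounds built on a shared core have numbers in an assay on isolated protein for displacement of a labelled ligand from Apoptosis regulator Bcl-2 (Homo sapiens), with a stated time of 15 min; a lower number here means a stronger inhibitor, a higher number a weaker inhibitor. Compound 1 `COc1ccc(C2=C(CN3CCN(c4ccc(C(=O)NS(=O)(=O)c5ccc(NCC6CCOCC6)c([N+](=O)[O-])c5)c(Oc5cnc6[nH]ccc6c5)c4)CC3)CCC(C)(C)C2)cc1` gives 3.8 nM. Compound 2 `CN(C)CCCNc1ccc(S(=O)(=O)NC(=O)c2ccc(N3CCN(CC4=C(c5ccc(C(F)(F)F)cc5)CC(C)(C)CC4)CC3)cc2Oc2cnc3[nH]ccc3c2)cc1[N+](=O)[O-]` gives 0.89 nM, and compound 3 `CC1(C)CCC(CN2CCN(c3ccc(C(=O)NS(=O)(=O)c4ccc(OCC5CCOCC5)c([N+](=O)[O-])c4)c(Oc4cnc5[nH]ccc5c4)c3)CC2)=C(c2ccc(C(F)(F)F)cc2)C1` gives 1 nM. Compound 3 thus holds the second highest of the three numbers: its nearest neighbour is compound 2, within the scatter, while compound 1 lies furthest away, beyond the scatter. For the measured compounds named here, the one single-point step among them, a 1.1-fold higher number from compound 2 to compound 3 (0.05 log units; within the scatter), replaced the (3-(dimethylamino)propyl)amino group with (oxan-4-yl)methoxy and moved the number by less than the scatter.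

Compound 4 `CN1CCC(COc2ccc(S(=O)(=O)NC(=O)c3ccc(N4CCN(CC5=C(c6ccc(C(F)(F)F)cc6)CC(C)(C)CC5)CC4)cc3Oc3cnc4[nH]ccc4c3)cc2[N+](=O)[O-])C1` carries a new change: 1-methylpyrrolidin-3-yl in place of oxan-4-yl on a saturated chain carbon bound to an oxygen on an aromatic ring. This is the same region altered in the step from compound 2 to compound 3, where an exchange of the whole side chain left the number essentially unchanged. On that basis the step is expected to stay within the scatter, no change at the digits printed from compound 3 to compound 4 (within the scatter). Compound 4 is therefore estimated at 1 nM, with a likely range from 0.4 nM to 2.5 nM.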

Compound 4, half-maximal inhibitory concentration: 0.75 nM
Beside the measured number, compound 4's estimate is 1.3-fold (0.12 log units) above it, and the stated range covers the measured number.
By their numbers in this assay, from the lowest: compounds 4, 2 and 3 (each within the scatter of the next); then compound 1.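

In this assay, 1-methylpyrrolidin-3-yl in place of oxan-4-yl gave a 1.3-fold lower number from compound 3 to compound 4 (0.12 log units; within the scatter) even though a five-membered ring with a nitrogen replaced a six-membered ring with an oxygen, so this position accepted a change of both ring size and hetero atom at the same count of heavy atoms. The exchange of the whole side chain gave a 1.2-fold lower number from compound 2 to compound 4 (0.07 log units; within the scatter) as well, which places the (3-(dimethylamino)propyl)amino, (oxan-4-yl)methoxy and (1-methylpyrrolidin-3-yl)methoxy groups all within the scatter of one another. Nothing available here accounts for this flat response. The compounds shown leave open whether the number would stay this flat with a carboxylic acid at the end of the side chain, or with a longer chain carrying the 1-methylpyrrolidin-3-yl ring. They also leave open whether any group on this aromatic carbon can move the number beyond the scatter.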